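The compounds below may be only part of what the source reports. "The series", "measured", "known", "first", "only" and "open" are said of these compounds alone.

In a functional assay on A549 cells (Homo sapiens) for cytotoxicity, read by MTT assay, with a stated time of 72 h (on this read-out lower numbers stand for stronger inhibition and higher numbers for weaker inhibition), compound 1 (`Cc1ccc(S(=O)(=O)c2nc3ccccc3nc2N2CCCC2)cc1`) gives > 50000 nM, which is a limit and not a number. Compound 2 (`COc1ccc(S(=O)(=O)c2nc3ccccc3nc2N2CCCC2)cc1`) gives > 50000 nM, also a limit. Compound 3 (`O=S(=O)(c1ccc(Br)cc1)c1nc2ccccc2nc1N1CCCC1`) gives > 50000 nM, again a limit. Compound 1 therefore stands at the limit of > 50000 nM in this assay, at which 3 of the 3 values shown sit, with no measured number beside it. Compound 4 (`Cc1ccc(S(=O)(=O)c2nc3ccccc3nc2N2CCc3ccccc3C2)cc1`) keeps the methyl group of compound 1 and differs elsewhere: 1,2,3,4-tetrahydroisoquinolin-2-yl in place of pyrrolidin-1-yl on an aromatic carbon. In words, 1,2,3,4-tetrahydroisoquinolin-2-yl stands in place of pyrrolidin-1-yl on an aromatic carbon. The measured changes are a step that the two limits leave unreadable from compound 1 to compound 2, a step that the two limits leave unreadable from compound 1 to compound 3 and a step that the two limits leave unreadable from compound 2 to compound 3. All three leave the pyrrolidin-1-yl in place and their sizes cannot be read, so they offer no direct measure of this change. With no direction favoured, no step beyond the scatter is expected in this assay. For compound 4 the estimated value is 40000 nM, with an expected range from 12000 nM to 100000 nM. Expressed as a change, this is an expected at least 1.2-fold lower number from compound 1 to compound 4 (0.09 log units; that floor lies within the scatter).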

Compound 4, half-maximal inhibitory concentration: > 50000 nM
Compound 4: only a limit was reported; the forecaster's own chance of this, stated with the estimate: 70%; middle value at least 1.2-fold (0.09 log units) from the limit.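

The step from compound 1 to compound 4 cannot be read, as both values are limits, so this result yields no new step: the limit of > 50000 nM in this assay, at which 4 of the 4 values shown sit.

The compounds shown leave open where the actual values of compound 1 to compound 4 lie, and so whether any of these changes alters the read-out in this assay.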